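The compounds below may be only part of what the source reports. "The series", "measured", "known", "first", "only" and "open" are said of these compounds alone.

Measured so far in a functional assay on MCF7 cells (Homo sapiens) for cytotoxicity, read by sulforhodamine B assay, with a stated time of 3 days; on this read-out lower numbers stand for stronger inhibition and higher numbers for weaker inhibition

- compound 1 `O=[N+]([O-])c1ccccc1S(=O)(=O)N1CC(n2cnc3c(Cl)nc(Cl)nc32)OCc2ccccc21` gives 383 nM
- compound 2 `O=[N+]([O-])c1ccccc1S(=O)(=O)N1CC(n2cnc3nc(Cl)nc(Cl)c32)OCc2ccccc21` gives 990 nM
- compound 3 `O=[N+]([O-])c1ccccc1S(=O)(=O)N1CC(n2cnc3c(Br)ncnc32)OCc2ccccc21` gives 3620 nM

Compound 3 has the highest number of the three, which makes it the weakest here. Compound 4 `O=[N+]([O-])c1ccc(S(=O)(=O)N2CC(n3cnc4c(Br)ncnc43)OCc3ccccc32)cc1` differs from it in one place: 4-nitrophenyl in place of 2-nitrophenyl on a sulfonyl sulfur, with 4-nitrophenyl in place of 2-nitrophenyl on a sulfonyl sulfur. The measured steps all keep 2-nitrophenyl and change only the group on a saturated ring carbon: a 2.6-fold higher number from compound 1 to compound 2 (0.41 log units; beyond the scatter), a 9.5-fold higher number from compound 1 to compound 3 (0.98 log units; beyond the scatter) and a 3.7-fold higher number from compound 2 to compound 3 (0.56 log units; beyond the scatter). None of them tests the new change, so no step beyond the scatter, in either direction, is expected in this assay, though those steps argue for a wide range. The estimated change is a 1.2-fold lower number from compound 3 to compound 4 (0.08 log units; within the scatter). For compound 4 the expected value is 3000 nM, with an estimated range of 1000 nM to 9000 nM.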

Compound 4, half-maximal inhibitory concentration: 1230 nM
Compound 4: middle estimate off by 2.4-fold (0.39 log units), on the high side, and the stated range covers the measured number.
By their numbers in this assay, from the lowest: compound 1; then compounds 2 and 4 (each within the scatter of the next); then compound 3.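

Swapping 2-nitrophenyl for 4-nitrophenyl on the sulfonyl sulfur gives a 2.9-fold lower number from compound 3 to compound 4 (0.47 log units; beyond the scatter) in this assay. Among the compounds shown here, the earlier steps changed only the group on the saturated ring carbon, so this is the first sign that the sulfonyl side also affects cytotoxicity, even though the two compounds have the same atoms, joined differently. Nothing measured here explains the difference. On these data alone, it remains open whether the same swap would give a similar step with the two-chlorine group of compound 1, and whether a plain phenyl or an aminophenyl would do better or worse than either nitrophenyl.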